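The source may report more compounds than this note shows. Statements on the series, on what has been measured and on what is new or still open speak of the compounds shown alone.

Compound 1 `Cn1ncc2c(=O)n(-c3ccccc3)c(/C=C/c3cccc(F)c3)nc21`: in a physicochemical assay for solubility, using the shake flask method, in phosphate buffer, with a stated time of 24 h, at pH 7.4 (on this read-out higher numbers stand for higher solubility and lower numbers for lower solubility), compound 1 gives 4000 nM.
Compound 2 `COc1cccc(C(C)Sc2nc3c(cnn3C)c(=O)n2-c2ccccc2)c1`: in this assay compound 2 gives only a limit, < 2000 nM.
Compound 3 `O=c1c2cncn2nc(SCc2cccc(F)c2)n1-c1ccccc1`: in this assay compound 3 gives 47000 nM.

Within the data shown here, of the three measured compounds, compound 2 is the one whose reading is not a number but a limit of the assay, and that is the limit of < 2000 nM in this assay, at which 1 of the 3 values shown sits. The other two compounds give numbers, with compound 3 showing the higher of the two and compound 1 the lower.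

The piece follows one change made to compound 2. The new compound is compound 4 `CC(Sc1nc2c(cnn2C)c(=O)n1-c1ccccc1)c1cccc(O)c1`, which has not yet been measured. The change is hydrogen in place of methyl on an oxygen on an aromatic ring. Among the measured compounds shown here, no measured pair with the same change is available here, so the size of the step can only be expected, not read off.

The expected step is an at least 2.0-fold higher number from compound 2 to compound 4 (0.30 log units; that floor lies within the scatter), a rise beyond the usual scatter but a modest one. Because compound 2 sits at the limit of < 2000 nM in this assay, at which 1 of the 3 values shown sits, the assay may again report only a limit rather than a number. Compound 4 is expected to come out at 4000 nM, within a range from 1500 nM to 12000 nM.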

Compound 4, solubility: 21000 nM
Compound 4: middle estimate off by 5.3-fold (0.72 log units), on the low side; the measured number lies above the stated range.
By their numbers in this assay, from the lowest: compound 1; then compound 4; then compound 3. At a limit, below all of these: compound 2.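

In this assay, going from 3-methoxyphenyl to 3-hydroxyphenyl gives an at least 10-fold higher number from compound 2 to compound 4 (1.02 log units; beyond the scatter), which shows that this single change, on an oxygen on an aromatic ring, can shift the read-out by a large amount. Among these compounds, the true size of the step remains unknown, and the printed size is only a floor, because compound 2 gives a limit of the assay rather than a number: the limit of < 2000 nM in this assay, at which 1 of the 4 values shown sits. This is also the first pair here that differs in only one place, so it gives the first direct reading of what one change does, which the earlier compounds could not offer.

The compounds shown leave open whether an amine or a carboxylic acid in place of the hydroxy group would shift the read-out in the same way. They also do not explain why compound 4 reads higher, or show whether the same change would give a similar step on another core.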